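A few compounds are considered here, and "the series" means these few. Any claim that something is new, unique, unknown or untested is made for them only; others in the source may bear on it.

Compound 1 `COc1ccc(-c2nc3cc(C(C)=O)ccc3[nH]2)c(OC)c1OC`: > 100000 nM (a limit)
Compound 2 `COc1ccc(-c2nc3cc(C(C)O)ccc3[nH]2)c(OC)c1`: > 100000 nM (a limit)

Both compounds were tested in an ADME assay on BHK-21 cells (Mesocricetus auratus) for cytotoxicity, read by MTT assay; a lower number here means that less compound is tolerated, a higher number that more compound is tolerated. Compound 2 gives > 100000 nM there, and this is a limit of the assay, not a number. Compound 1 gives > 100000 nM, which is likewise a limit. Neither compound therefore has a number, and the record holds only (the limit of > 100000 nM in this assay, at which 2 of the 2 values shown sit).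

Compound 3 `COc1ccc(-c2nc3cc(C(C)O)ccc3[nH]2)c(OC)c1OC` follows from compound 2 with methoxy in place of hydrogen on an aromatic carbon. The new group sits ortho to two methoxy groups and meta to a large group. Going by the values given here, no measured step shows what such a change does in this assay, so the expectation rests on the values alone. A step within the scatter is expected because compound 2 stands at > 100000 nM, a limit. The estimated step of a number no higher from compound 2 to compound 3 (the limit leaves the size open) is accordingly expected to stay within the scatter, in neither direction. For compound 3 the estimate is 100000 nM, with an expected range from 50000 nM to 200000 nM, and the assay is expected to report a limit again.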

Compound 3, half-maximal cytotoxic concentration: 60000 nM
Beside the measured number, compound 3's estimate is 1.7-fold (0.22 log units) above it; the measured number falls inside the stated range.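

In this assay, going by these compounds alone, compound 3 is the only one of the three compounds with a number rather than a limit, so the methoxy group, ortho to two methoxy groups and meta to a large group, can now be given a step: methoxy in place of hydrogen on an aromatic carbon gives an at least 1.6-fold lower number from compound 2 to compound 3 (0.22 log units; that floor lies within the scatter). Compound 3 also allows a reading of the other change, since 1-hydroxyethyl in place of acetyl on an aromatic carbon gives an at least 1.6-fold lower number from compound 1 to compound 3 (0.22 log units; that floor lies within the scatter). Both steps are only floors, and their true size stays open because the values of compound 1 and compound 2 are limits: the limit of > 100000 nM in this assay, at which 2 of the 3 values shown sit.

The compounds shown therefore leave open whether either step reaches beyond the scatter, and so whether the added methoxy group or the change from acetyl to 1-hydroxyethyl lowers the number at all in this assay. They also leave open what an amine or a carboxylic acid at the place of the new methoxy group, or a longer chain in place of the 1-hydroxyethyl group, would give there.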